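Replacing an Ethynyl Arm with a Chlorophenyl Group

This account rests on a few compounds, and the source may have more. Where it says the series, first, only, none or still open, it means among the compounds named here.

Compound 1 `Nc1ncnn2c([C@@H]3O[C@H](CO)[C@@H](O)[C@H]3O)cc(C#Cc3ccc(F)cc3)c12`: 89000 nM
Compound 2 `Nc1ncnn2c([C@@H]3O[C@H](CO)[C@@H](O)[C@H]3O)cc(C#Cc3cccs3)c12`: 50100 nM

Of the compounds shown here, two have been measured in a functional assay on Z-138 cells (Homo sapiens) for antiproliferative activity, with a stated time of 72 h; a lower number here means a stronger inhibitor, a higher number a weaker inhibitor. Compound 1 gives 89000 nM and compound 2 gives 50100 nM. Of the two numbers, that of compound 2 is the smaller, but the step of a 1.8-fold lower number from compound 1 to compound 2 (0.25 log units; within the scatter) lies within the scatter, so the two compounds stand level rather than in any order.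

Compound 3 `Nc1ncnn2c([C@@H]3O[C@H](CO)[C@@H](O)[C@H]3O)cc(-c3ccc(Cl)cc3)c12` has not yet been measured. Its change from compound 2 is 4-chlorophenyl in place of 2-(thiophen-2-yl)ethynyl on an aromatic carbon. Within the data shown here, the single measured step, a 1.8-fold lower number from compound 1 to compound 2 (0.25 log units; within the scatter), exchanged one aromatic ring for another while the triple bond stayed in place; no measured pair speaks to removing the triple bond and placing a ring directly on the aromatic carbon. The expectation for compound 3 therefore rests on compound 2 alone and carries a wide range. For compound 3 the step is expected to stay within the scatter, at a 1.2-fold higher number from compound 2 to compound 3 (0.08 log units; within the scatter). Compound 3 is estimated at 60000 nM, within 15000 nM to 200000 nM.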

Compound 3, half-maximal inhibitory concentration: 40200 nM
Compound 3: middle estimate off by 1.5-fold (0.17 log units), on the high side; measured number inside the range.
By their numbers in this assay, from the lowest: compounds 3, 2 and 1 (each within the scatter of the next, the first and the last beyond it).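

In this assay, the triple bond proved dispensable at this position, an aromatic carbon two ring bonds from the ring nitrogen: a 4-chlorophenyl ring set directly on that carbon in place of 2-(thiophen-2-yl)ethynyl gave a 1.2-fold lower number from compound 2 to compound 3 (0.10 log units; within the scatter), and the two stand level. Against 2-(4-fluorophenyl)ethynyl, the same exchange gave a 2.2-fold lower number from compound 1 to compound 3 (0.35 log units; beyond the scatter), the first step among these compounds to pass beyond the scatter, though only a modest one, and it rests on a pair whose partner, compound 2, stays within the scatter of both others. No evidence is available that accounts for either step.

What remains open is which part of the exchange carries the step from the 2-(4-fluorophenyl)ethynyl group, the loss of the triple bond or the ring with its chlorine, since the compounds shown change both together. Nor do they say whether a plain phenyl, an amine or a carboxylic acid in place of the chlorine, or a methyl group on the aromatic carbon itself, would move the number in this assay any further.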